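Extending the ring nitrogen substituent of compound 2

A few compounds are considered here, and "the series" means these few. Any claim that something is new, unique, unknown or untested is made for them only; others in the source may bear on it.

Of the compounds shown here, two have been measured in an assay for inhibition of Amine oxidase [flavin-containing] A (Bos taurus), read by fluorescence, with a stated time of 30 min; a lower number here means a stronger inhibitor, a higher number a weaker inhibitor. Compound 1 `CCn1ccc(N2C[C@H](CO)OC2=O)c1` gives 3 nM in this assay. Compound 2 `COC[C@H]1CN(c2ccn(C)c2)C(=O)O1` gives 300 nM in this assay, the higher of the two numbers, and its distance from compound 1 lies well beyond the scatter of repeated measurements. Among the measured compounds shown here, no single-point change connects these two compounds, so no step between measured compounds can be read off.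

Compound 3 `CCn1ccc(N2C[C@H](COC)OC2=O)c1` has not been measured. It differs from compound 2 by methyl in place of hydrogen on a saturated chain carbon bound to an aromatic nitrogen; seen one bond further out, the change reads methyl to ethyl. Compound 1, the stronger of the two measured compounds, carries the same ethyl on its ring nitrogen, but it also differs from compound 2 elsewhere, so how much of its lower number belongs to the ethyl cannot be told. The step is therefore expected to go toward a lower number, of moderate size, as a 5.0-fold lower number from compound 2 to compound 3 (0.70 log units; beyond the scatter). Compound 3 is estimated at 60 nM in this assay, within a range from 10 nM to 300 nM.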

Compound 3, inhibition constant: 0.6 nM
Estimate against measurement, compound 3: 100-fold (2.00 log units) above; the measured number lies below the stated range.
By their numbers in this assay, from the lowest: compound 3; then compound 1; then compound 2.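

In this assay, methyl in place of hydrogen on a saturated chain carbon bound to an aromatic nitrogen gives a 500-fold lower number from compound 2 to compound 3 (2.70 log units; beyond the scatter), so this one change, which the earlier pair could not isolate, now has a size of its own, and that size is large. The result also isolates a second place: methyl in place of hydrogen on an oxygen on a saturated carbon gives a 5.0-fold lower number from compound 1 to compound 3 (0.70 log units; beyond the scatter), a modest step in the same direction, which shows that the ethyl compound does not depend on a free hydrogen on that oxygen to reach a low number. Nothing measured here explains either step.

The compounds shown stop at ethyl, so it remains open whether a longer chain such as propyl, a branched isopropyl or a cyclopropyl ring at this place would continue the trend or reverse it. Going by these compounds, it is also open whether larger groups on the oxygen, such as ethyl or benzyl, would be accepted as well as methyl, and whether either step would carry over to another assay.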